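A Nitro Group Added to Compound 1

The compounds below may be only part of what the source reports. "The series", "measured", "known", "first", "only" and "open" are said of these compounds alone.

compound 1 `Cc1ccccc1/N=C(/N)Nc1cccc(O)c1` — 155 nM
compound 2 `Cc1ccccc1/N=C(/N)Nc1ccc(N)cc1C` — 220 nM

Of the compounds shown here, two have so far been measured in an assay on membranes from brain (Cavia porcellus) for binding affinity to Sigma non-opioid intracellular receptor 1 (Homo sapiens); on this read-out higher numbers stand for weaker inhibition and lower numbers for stronger inhibition. Compound 1 gives 155 nM, and compound 2 gives 220 nM; these two values lie within the scatter of each other, so they cannot be told apart. Compound 3 `Cc1cc([N+](=O)[O-])ccc1/N=C(/N)Nc1cccc(O)c1` has not yet been measured. It differs from compound 1 by nitro in place of hydrogen on an aromatic carbon. Among the compounds with values here, no measured pair shows what such a change does here. For compound 3 a value of 250 nM is expected, with a range from 80 nM to 800 nM. The expected step of a 1.6-fold higher number from compound 1 to compound 3 (0.21 log units; within the scatter) is a small one toward weaker inhibition, hardly beyond the scatter.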

Compound 3, half-maximal inhibitory concentration: 94 nM
For compound 3 the middle estimate is 2.7-fold (0.42 log units) above the measured one; measured number inside the range.
By their numbers in this assay, from the lowest: compounds 3, 1 and 2 (each within the scatter of the next, the first and the last beyond it).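

In this assay, nitro in place of hydrogen on this aromatic carbon, para to a large group and meta to a methyl group, gives a 1.6-fold lower number from compound 1 to compound 3 (0.22 log units; within the scatter) and so no change that can be told apart from the scatter. This position therefore takes on the three extra heavy atoms of nitro without a measurable loss of binding, though a single pair shows this for this core only. Nothing measured here bears on the reason for this result. From the compounds shown here alone, whether an amine or a carboxylic acid at the same carbon would fare the same stays open.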